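Methyl-to-nitro swap on the aryl ring of compound 3

The source may hold more compounds than are shown below. What is called first, only, known or untested is meant among the compounds shown, and "the series" means these compounds.

Measured compounds in an assay for displacement of a labelled ligand from Sigma non-opioid intracellular receptor 1 (Cavia porcellus); on this read-out lower numbers stand for stronger inhibition and higher numbers for weaker inhibition:
- compound 1 `COC(=O)C1(c2ccc(C)cc2)CC1CN1CCN(c2ncccn2)CC1`: 353 nM
- compound 2 `COC(=O)C1(c2ccc(N)cc2)CC1CN1CCN(c2ncccn2)CC1`: a limit, > 10000 nM
- compound 3 `COC(=O)C1(c2ccc(C)cc2)CC1CN1CCN(c2ccccn2)CC1`: 497 nM

Compound 3 has the highest of the two numbers given; its nearest neighbour is compound 1, with a 1.4-fold higher number from compound 1 to compound 3 (0.15 log units; within the scatter), so the two are not separated. For compound 2 the assay reports only a limit, > 10000 nM, not a number.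

Compound 4 `COC(=O)C1(c2ccc([N+](=O)[O-])cc2)CC1CN1CCN(c2ccccn2)CC1` differs from compound 3 by nitro in place of methyl on an aromatic carbon. Among the compounds with values here, no measured step involves a nitro group. Within the data shown here, the only step at the same position is the one in which amino replaces methyl, an at least 28-fold higher number from compound 1 to compound 2 (1.45 log units; beyond the scatter), which runs into the limit (the limit of > 10000 nM in this assay, at which 1 of the 3 values shown sits). That change and the present one are both replacements of methyl by a group carrying heteroatoms on the aromatic carbon, so a weakening step is expected for compound 4, a 6.0-fold higher number from compound 3 to compound 4 (0.78 log units; beyond the scatter), though smaller than the amino case is plausible. Compound 4 is estimated at 3000 nM, within 800 nM to 12000 nM, with a fair chance that only a limit is returned.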

Compound 4, inhibition constant: 769 nM
For compound 4 the middle estimate is 3.9-fold (0.59 log units) above the measured one, outside the stated range (below it).
By their numbers in this assay, from the lowest: compounds 1, 3 and 4 (each within the scatter of the next, the first and the last beyond it). At a limit, above all of these: compound 2.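

In this assay, nitro in place of methyl on the aromatic carbon gives a 1.5-fold higher number from compound 3 to compound 4 (0.19 log units; within the scatter), so this carbon can carry a group with heteroatoms without a separation from the methyl compound. The earlier amino change, an at least 28-fold higher number from compound 1 to compound 2 (1.45 log units; beyond the scatter), therefore does not describe every heteroatom-bearing replacement here, although that step was read with pyrimidin-2-yl on the amine nitrogen and the nitro step with pyridin-2-yl. Compound 2 remains a limit and not a number: the limit of > 10000 nM in this assay, at which 1 of the 4 values shown sits.

The compounds shown leave open whether amino and nitro would part in the same way with the same group on the amine nitrogen, as each is seen with only one of the two. They also leave open where a carboxylic acid, a methoxy group or a chlorine atom on the same aromatic carbon would fall.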